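From pyridin-3-yl to 1,3-thiazol-5-yl on compound 1

A few compounds are considered here, and "the series" means these few. Any claim that something is new, unique, unknown or untested is made for them only; others in the source may bear on it.

Measured so far in a functional assay (trachea) with Cavia porcellus as the target; on this read-out lower numbers stand for stronger inhibition and higher numbers for weaker inhibition:
- compound 1 `CCn1nc(-c2cccnc2)c2ccccc2c1=O`: 1320 nM
- compound 2 `O=c1c2ccccc2c(-c2cccnc2)nn1CCSc1ccccc1`: 9120 nM
- compound 3 `NCCn1nc(-c2cccnc2)c2ccccc2c1=O`: > 100000 nM, which is a limit of the assay and not a number

Compound 1 gives the lowest number of the three. The nearest measured value comes with a 6.9-fold higher number from compound 1 to compound 2 (0.84 log units; beyond the scatter), while the limit reported for compound 3 lies further up, as an at least 75-fold higher number from compound 1 to compound 3 (1.87 log units; beyond the scatter) shows.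

Compound 4 `CCn1nc(-c2cncs2)c2ccccc2c1=O` keeps the ethyl group and the shared core of compound 1. It differs in one place, with 1,3-thiazol-5-yl in place of pyridin-3-yl on an aromatic carbon.

Going by the values given here, none of the measured steps touches this aromatic group. The modest step to compound 2 and the large step to compound 3 both change a saturated chain carbon instead, so they show how far the numbers can move at that other place but give no direct guide to this exchange. Among the compounds with values here, with no measured step pointing either way, the expected step in this assay is a 1.1-fold higher number from compound 1 to compound 4 (0.06 log units; within the scatter), and no direction is favoured. Compound 4 is estimated at 1500 nM. For compound 4 the expected range runs from 400 nM to 6000 nM.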

Compound 4, half-maximal inhibitory concentration: 562 nM
Estimate against measurement, compound 4: 2.7-fold (0.43 log units) above; the measured number falls inside the stated range.
By their numbers in this assay, from the lowest: compound 4; then compound 1; then compound 2. At a limit, above all of these: compound 3.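

In this assay, going by these compounds alone, the exchange of pyridin-3-yl for 1,3-thiazol-5-yl gives a 2.3-fold lower number from compound 1 to compound 4 (0.37 log units; beyond the scatter) and so shows that this aromatic carbon, untouched by the earlier steps, is a place where the number can move. The step is modest, yet it is the first one shown that lowers the number, whereas every earlier step, all of them on the saturated chain, raised it. It also shows that the six-membered aromatic ring with one hetero atom can give way to a five-membered aromatic ring with two hetero atoms, one of them sulfur, with no loss on this read-out, although no measurement shown bears on why the number falls.

This exchange alters ring size and ring atoms together, so the compounds shown leave open which of these changes matters, a question that a thiophene ring or a phenyl ring at the same place could help to separate. They also leave open whether the lower number carries over when the ethyl group gives way to a longer chain such as propyl.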